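Methylsulfonyl in place of trifluoromethoxy, starting from a limit

This account rests on a few compounds, and the source may have more. Where it says the series, first, only, none or still open, it means among the compounds named here.

For the measured compounds named here, in a functional assay for inhibition, with Rattus norvegicus as the target (a lower number here means a stronger inhibitor, a higher number a weaker inhibitor), compound 1 `CC(C)(C)/N=c1\c(O)c(O)\c1=N/c1cccc2cnccc12` gives 1840 nM, the only full number so far. Compound 2 `CC(/N=c1\c(O)c(O)\c1=N/c1ccc(OC(F)(F)F)cc1)C(C)(C)C` reads > 30000 nM, which is a limit of the assay and not a number. The series therefore shows (the limit of > 30000 nM in this assay, at which 1 of the 2 values shown sits).

Compound 3 `CC(/N=c1\c(O)c(O)\c1=N/c1ccc(S(C)(=O)=O)cc1)C(C)(C)C` differs from compound 2 by methylsulfonyl in place of trifluoromethoxy on an aromatic carbon, para to a large group. Going by the values given here, no measured step covers this exchange, so its size remains uncalibrated, and any numerical reading for compound 3 would lie on the stronger side of the limit. The estimated step, an at least 5.0-fold lower number from compound 2 to compound 3 (0.69 log units; beyond the scatter), is toward stronger inhibition in this assay, although the reading may stay at the limit. For compound 3 the expected value is 6000 nM, with an estimated range of 800 nM to 30000 nM.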

Compound 3, half-maximal inhibitory concentration: > 30000 nM
Compound 3 ended at the assay's limit; the forecaster's own chance of this, stated with the estimate: 30%; middle value at least 5.0-fold (0.69 log units) from the limit.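

In this assay compound 2 reads > 30000 nM, a limit of the assay and not a number. For the compounds shown here, compound 3 reads > 30000 nM, also a limit, so no step between compound 2 and compound 3 can be read. As far as these compounds go, whether methylsulfonyl or trifluoromethoxy gives the stronger inhibitor stays open.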